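Propargyl to Benzyl: Expecting Another Limit

A few compounds are considered here, and "the series" means these few. Any claim that something is new, unique, unknown or untested is made for them only; others in the source may bear on it.

Compound 1 `C#CCN1CCC(OC(=O)Nc2ccccc2)CC1` in an assay on BTI-TN-5B1-4 cells for inhibition of Amine oxidase [flavin-containing] A (Homo sapiens), read by fluorescence and Amplex Red, using microsomes, with a stated time of 15 min (on this read-out higher numbers stand for weaker inhibition and lower numbers for stronger inhibition), gives > 100000 nM, which is a limit of the assay rather than a number.
Compound 2 `C#CCN1CCCC(OC(=O)Nc2ccccc2)C1` in this assay gives > 100000 nM, again a limit.
Compound 3 `O=C(Nc1ccccc1)OC1CCN(Cc2ccccc2)CC1` in this assay gives > 100000 nM, also a limit.

Among the compounds with values here, compound 2 therefore stands only at a limit, and every value known so far sits there too (the limit of > 100000 nM in this assay, at which 3 of the 3 values shown sit). The new compound, compound 4 `O=C(Nc1ccccc1)OC1CCCN(Cc2ccccc2)C1`, differs from compound 2 in one place: phenyl in place of ethynyl on a saturated chain carbon bound to an amine nitrogen in a ring. Within the data shown here, the only measured step that carries the same change is the one from compound 1 to compound 3, and it reads a step that the two limits leave unreadable from compound 1 to compound 3, because both of its ends are limits. It gives no hint of direction or size, and nothing else among the measured compounds speaks to the change. The expectation is that compound 4 will most likely again fall at the limit, so the step that the limit leaves unreadable from compound 2 to compound 4 is expected to be unreadable or small. Compound 4 is thus estimated at 150000 nM, within a range from 50000 nM to 500000 nM.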

Compound 4, half-maximal inhibitory concentration: > 100000 nM
Compound 4 gave a limit, no number; the forecaster's own chance of this, stated with the estimate: 85%; the middle value does not contradict the limit.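

Within the data shown here, compound 2 and compound 4 both sit at a limit in this assay and give no number, so no step between them can be read. The compounds shown leave open which change to the shared core, if any, would give a measured number instead of a limit.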